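The source may hold more compounds than are shown below. What is called first, only, known or untested is meant among the compounds shown, and "the series" means these compounds.

Compound 1 `Cc1ccccc1C(=O)NNC(=O)c1cccc(NS(=O)(=O)c2cnc(O)nc2O)c1` is measured in a functional assay on SGC-7901 cells (Homo sapiens) for antiproliferative activity, read by MTT assay, with a stated time of 24 h; a higher number here means a weaker inhibitor, a lower number a stronger inhibitor. In this assay compound 1 gives > 20000 nM, a limit of the assay rather than a number.
Compound 2 `Cc1ccc(C(=O)NNC(=O)c2cccc(NS(=O)(=O)c3cnc(O)nc3O)c2)cc1` gives 10100 nM in this assay.
Compound 3 `Cc1ccccc1C(=O)NNC(=O)c1ccccc1NS(=O)(=O)c1cnc(O)nc1O` gives 13000 nM in this assay.

The change from compound 1 to compound 2, (4-methylphenyl in place of 2-methylphenyl on a carbonyl carbon), made a step of an at least 1.9-fold lower number from compound 1 to compound 2 (0.29 log units; that floor lies within the scatter); because compound 1 sits at the limit of > 20000 nM in this assay, at which 1 of the 3 values shown sits, only a floor for that step is known. The two values of compound 2 and compound 3 lie within the usual scatter of each other, so no order between them is claimed. Compound 4 `Cc1ccc(C(=O)NNC(=O)c2ccccc2NS(=O)(=O)c2cnc(O)nc2O)cc1` has not yet been measured. It differs from compound 3 by 4-methylphenyl in place of 2-methylphenyl on a carbonyl carbon, the same change that led from compound 1 to compound 2, made at the same place. The difference between the core of compound 1 and the core of compound 3 is not broken down here. Resting on the step from compound 1 to compound 2 an at least 1.9-fold lower number from compound 1 to compound 2 (0.29 log units; that floor lies within the scatter), a step of similar size is expected from compound 3 to compound 4, a 1.9-fold lower number from compound 3 to compound 4 (0.27 log units; within the scatter). Compound 4 is therefore estimated at 7000 nM, expected to lie between 3000 nM and 16000 nM.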

Compound 4, half-maximal inhibitory concentration: 15500 nM
For compound 4 the middle estimate is 2.2-fold (0.35 log units) below the measured one; low and high end bracket the measured number.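

On the second core, 4-methylphenyl in place of 2-methylphenyl gave a 1.2-fold higher number from compound 3 to compound 4 (0.08 log units; within the scatter) in this assay, so on this core the change has no effect that can be told from the scatter. Set beside the step on the first core, this result cannot be separated from it: the same change on two cores in this assay, an at least 1.9-fold lower number (0.29 log units; that floor lies within the scatter) from compound 1 to compound 2 and a 1.2-fold higher number (0.08 log units; within the scatter) from compound 3 to compound 4; the limit leaves it open whether they differ The pair therefore gives no evidence that the change reliably lowers the number on both cores, but it does not show that the change behaves differently on them either, since the step on the first core is only a floor set by an assay limit: the limit of > 20000 nM in this assay, at which 1 of the 4 values shown sits.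

The compounds shown carry only 2-methylphenyl or 4-methylphenyl on the carbonyl carbon, and all their values come from a single cell assay with one stated time. On these data alone, it remains open whether an unsubstituted phenyl, a chlorophenyl, a methoxyphenyl, an aminophenyl or a carboxyphenyl in that place would shift the number on either core.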